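From a silicon-bearing group to methoxymethoxy

The source may hold more compounds than are shown below. What is called first, only, known or untested is meant among the compounds shown, and "the series" means these compounds.

Among the compounds with values here, in a functional assay on MCF7 cells (Homo sapiens) for antiproliferative activity, read by MTT assay, with a stated time of 48 h (on this read-out lower numbers stand for stronger inhibition and higher numbers for weaker inhibition), compound 2 `CC(C)=CCC[C@]1(C)/C=C/[C@@H](OC(=O)C=C(C)C)[C@](C)(O)/C=C/C(=O)/C(C[Si](C)(C)C(C)(C)C)=C\C1` gives 6040 nM and stands highest of the numbers so far, while compound 1 `CC(C)=CCC[C@]1(C)/C=C/[C@@H](OC(=O)C=C(C)C)[C@](C)(O)/C=C/C(=O)/C(CN2CCCC2)=C\C1` gives 220 nM on the same core. Compound 3 `COCOC/C1=C/C[C@](C)(CCC=C(C)C)/C=C/[C@@H](OC(=O)C=C(C)C)[C@](C)(O)/C=C/C1=O` differs from compound 2 by a group of 4 heavy atoms (2 carbon, 2 oxygen; no ring) in place of a group of 7 heavy atoms (6 carbon, 1 silicon; no ring), on a saturated chain carbon bound to a double-bonded ring carbon in its side group. Within the data shown here, only one measured step bears on this place, a 27-fold higher number from compound 1 to compound 2 (1.44 log units; beyond the scatter) in size, and it shows that a change here can move the number widely. A moderate move toward a lower number is expected, with a 4.0-fold lower number from compound 2 to compound 3 (0.60 log units; beyond the scatter) as the estimated step in this assay for now. For compound 3 the estimate is 1500 nM with an expected range of 350 nM to 6000 nM in this read-out.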

Compound 3, half-maximal inhibitory concentration: 3120 nM
Compound 3: middle estimate off by 2.1-fold (0.32 log units), on the low side; low and high end bracket the measured number.
By their numbers in this assay, from the lowest: compound 1; then compounds 3 and 2 (each within the scatter of the next).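

Replacing the silicon-bearing group with methoxymethoxy gives a 1.9-fold lower number from compound 2 to compound 3 (0.29 log units; within the scatter) in this assay, so the number does not separate these two groups at this saturated chain carbon. Pyrrolidin-1-yl stands apart from both: methoxymethoxy in its place gives a 14-fold higher number from compound 1 to compound 3 (1.15 log units; beyond the scatter), so the large step seen earlier does not depend on the silicon-bearing group alone. Nothing at hand accounts for this gap.

As far as these compounds go, whether another amine, such as piperidin-1-yl or dimethylamino, would match compound 1 remains open. So does the outcome with a carboxylic acid on this carbon.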